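A few compounds are considered here, and "the series" means these few. Any claim that something is new, unique, unknown or untested is made for them only; others in the source may bear on it.

Compound 1, `CCC(=O)Nc1ccc(S(=O)(=O)Oc2ccccc2C(C)C)cc1`, in a functional assay on HT-1080 cells (Homo sapiens) for antiproliferative activity, read by sulforhodamine B assay, with a stated time of 48 h; a lower number here means a stronger inhibitor, a higher number a weaker inhibitor: 2100 nM
Compound 2, `CC(C)c1ccccc1OS(=O)(=O)c1ccc(NC(=O)C(C)(C)C)cc1`: 11000 nM
Compound 3, `CC(C)(C)C(=O)Nc1ccc(S(=O)(=O)Oc2ccccc2I)cc1`: 2600 nM

Compound 3 stands second highest of these three numbers. Its nearest neighbour is compound 1, and the two fall within the scatter of each other, so no order can be read between them. Compound 2 is the far end, reached by the step of a 4.2-fold lower number from compound 2 to compound 3 (0.63 log units; beyond the scatter) in the reverse direction.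

Compound 4 is `CCCCCNC(=O)Nc1ccc(S(=O)(=O)Oc2ccccc2I)cc1`. The change from compound 3 is pentylamino in place of tert-butyl on a carbonyl carbon. Of the two measured steps, only a 5.2-fold higher number from compound 1 to compound 2 (0.72 log units; beyond the scatter) took place at this same carbonyl carbon, and it raised the number when tert-butyl entered; the other step, at an aromatic carbon, does not bear on it. Because the step of a 5.2-fold higher number from compound 1 to compound 2 (0.72 log units; beyond the scatter) raised the number when tert-butyl entered at this same carbonyl carbon, removing it again in compound 4 is expected to give a modest lowering, a 1.7-fold lower number from compound 3 to compound 4 (0.24 log units; within the scatter). Pentylamino itself has not been tried here, so the expectation is loose. Compound 4 is therefore estimated at 1500 nM, with a range of 500 nM to 5000 nM.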

Compound 4, half-maximal inhibitory concentration: 6900 nM
Compound 4: the middle estimate sits 4.6-fold (0.66 log units) below what was measured, outside the stated range (above it).
By their numbers in this assay, from the lowest: compounds 1 and 3 (each within the scatter of the next); then compounds 4 and 2 (each within the scatter of the next).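

Removing tert-butyl from this carbonyl carbon does not by itself lower the number: with pentylamino in its place, the assay this assay gives a 2.7-fold higher number from compound 3 to compound 4 (0.42 log units; beyond the scatter). The only earlier step at this carbon, a 5.2-fold higher number from compound 1 to compound 2 (0.72 log units; beyond the scatter), also raised the number, so on the evidence of these compounds, both a tert-butyl entering and a pentylamino entering can weaken activity, each on its own version of the core. Nothing available here explains the rise seen with pentylamino.

The added nitrogen and the length of the chain enter together, so their shares in this rise remain unseparated; a shorter chain such as ethylamino, or a plain hexyl group on the carbonyl carbon, would pull them apart. Going by these compounds, whether pentylamino acts the same way when isopropyl replaces iodo also stays open.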